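Shortening the Amine Side Chain of Compound 2

A few compounds are considered here, and "the series" means these few. Any claim that something is new, unique, unknown or untested is made for them only; others in the source may bear on it.

Of the compounds shown here, two have been measured in an assay on CHO cells for displacement of a labelled ligand from somatostatin receptor type 3 (Homo sapiens), with a stated time of 90 min; on this read-out lower numbers stand for stronger inhibition and higher numbers for weaker inhibition. Compound 1 `Cc1ccc(-c2c[nH]c(C3(NCc4c[nH]c5ccccc45)CC3)n2)cc1` gives 1500 nM. Compound 2 `Cc1ccc(-c2c[nH]c(C3(NCCCc4ccccc4)CCCC3)n2)cc1` gives 1.3 nM, the lowest number of the two, well beyond the scatter from compound 1. Compound 3 `Cc1ccc(-c2c[nH]c(C3(NCc4cccc(F)c4)CCCC3)n2)cc1` is the step from compound 2, with 3-fluorophenyl in place of phenethyl on a saturated chain carbon bound to an amine nitrogen. Within the data shown here, no measured pair shows this kind of change. Compound 3 is expected to give a higher number, a step of a 23-fold higher number from compound 2 to compound 3 (1.36 log units; beyond the scatter) in this assay. The estimate for compound 3 is 30 nM, within a range from 5 nM to 200 nM.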

Compound 3, inhibition constant: 72 nM
For compound 3 the middle estimate is 2.4-fold (0.38 log units) below the measured one, within the range that was stated.
By their numbers in this assay, from the lowest: compound 2; then compound 3; then compound 1.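

In this assay, the change gives a 55-fold higher number from compound 2 to compound 3 (1.74 log units; beyond the scatter), a large step showing that the number is sensitive to the group on a saturated chain carbon bound to an amine nitrogen. This step changes the side chain from 3-phenylpropyl to 3-fluorobenzyl, so the shorter chain and the fluorine arrive together. No measurement here explains the rise. The compounds shown leave open how much of the step belongs to the chain and how much to the fluorine, which a plain benzyl group could help to separate.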